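A few compounds are considered here, and "the series" means these few. Any claim that something is new, unique, unknown or untested is made for them only; others in the source may bear on it.

Measured in a functional assay on HepG2 cells (Homo sapiens) for cytotoxicity, with a stated time of 24 h; a lower number here means a stronger inhibitor, a higher number a weaker inhibitor:
Compound 1 `COc1ccc(Cl)cc1C(=S)Nc1cc(Cl)ccc1O`: 8600 nM
Compound 2 `COc1ccc(Cl)cc1C(=S)Nc1cc(Br)ccc1O`: 8740 nM

Among the measured compounds shown here, only these two compounds have numbers so far, and compound 2 cannot be told apart from compound 1. The swap of chloro for bromo on the same aromatic carbon gives a 1.0-fold higher number from compound 1 to compound 2 (0.01 log units; within the scatter).

The next compound is compound 3 `COc1ccc(Cl)cc1C(=S)Nc1cc(C(F)(F)F)ccc1O`, with trifluoromethyl in place of bromo on an aromatic carbon. This group also sits para to a hydroxy group. For the measured compounds named here, the single measured step bearing on this change is a 1.0-fold higher number from compound 1 to compound 2 (0.01 log units; within the scatter), and no compound with trifluoromethyl has been tested yet. That one step gives weak guidance, so no shift beyond the scatter is expected in this assay, although the uncertainty is wide. The expected step is a 1.1-fold lower number from compound 2 to compound 3 (0.04 log units; within the scatter). For compound 3 the estimated value is 8000 nM, with an expected range of 3500 nM to 18000 nM.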

Compound 3, half-maximal inhibitory concentration: 5860 nM
Compound 3: the middle estimate sits 1.4-fold (0.14 log units) above what was measured, within the range that was stated.
By their numbers in this assay, from the lowest: compounds 3, 1 and 2 (each within the scatter of the next).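

Trifluoromethyl, with 4 heavy atoms where bromo has 1, gives a 1.5-fold lower number from compound 2 to compound 3 (0.17 log units; within the scatter) in this assay and, set against chloro, a 1.5-fold lower number from compound 1 to compound 3 (0.17 log units; within the scatter) on the same carbon. So at this carbon, para to a hydroxy group, chloro, bromo and trifluoromethyl cannot be told apart in this assay, and the larger group brings no step beyond the scatter. Nothing measured here accounts for this lack of separation.

All three groups leave the hydroxy group and the rest of the shared core unchanged, so they say nothing about how much those parts matter. On these data alone, it also remains open whether an amine, a carboxylic acid or a longer chain on this carbon would move the number beyond the scatter.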